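A few compounds are considered here, and "the series" means these few. Any claim that something is new, unique, unknown or untested is made for them only; others in the source may bear on it.

Of the compounds shown here, two built on the same core have been tested in an assay on isolated protein for inhibition of Amine oxidase [flavin-containing] B (Homo sapiens), read by fluorescence and Amplex Red, with a stated time of 30 min; a lower number here means a stronger inhibitor, a higher number a weaker inhibitor. Compound 1 `N#Cc1ccc(-c2csc(N/N=C/c3ccc(N4CCCC4)cc3)n2)cc1` gives 53100 nM in this assay. Compound 2 `Fc1ccc(-c2csc(N/N=C/c3ccc(N4CCCC4)cc3)n2)cc1` gives 426000 nM in this assay, the higher of the two numbers and so the weaker inhibitor of the pair. For the measured compounds named here, the only measured step joins them: an 8.0-fold higher number from compound 1 to compound 2 (0.90 log units; beyond the scatter).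

Compound 3 `Clc1ccc(-c2csc(N/N=C/c3ccc(N4CCCC4)cc3)n2)c(Cl)c1` differs from compound 2 in one place: 2,4-dichlorophenyl in place of 4-fluorophenyl on an aromatic carbon. Going by the values given here, no measured step covers this swap directly. Among the compounds with values here, the one step that touches the same aromatic carbon, an 8.0-fold higher number from compound 1 to compound 2 (0.90 log units; beyond the scatter), shows that changing the group on the phenyl ring there shifts the number beyond the scatter but only modestly. Within the data shown here, two chlorines have no precedent among the measured compounds, so the direction is uncertain; a modest move in either direction, or none beyond the scatter, would fit. Compound 3 is therefore expected to give about 200000 nM in this assay, most likely between 40000 nM and 1000000 nM. The expected step is a 2.1-fold lower number from compound 2 to compound 3 (0.33 log units; beyond the scatter).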

Compound 3, half-maximal inhibitory concentration: 131000 nM
Compound 3: the middle estimate sits 1.5-fold (0.18 log units) above what was measured; measured number inside the range.
By their numbers in this assay, from the lowest: compound 1; then compound 3; then compound 2.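

In this assay, the third group tested on this aromatic carbon ranks in the middle: the swap from 4-fluorophenyl to 2,4-dichlorophenyl lowers the number (a 3.3-fold lower number from compound 2 to compound 3 (0.51 log units; beyond the scatter)), while the swap from 4-cyanophenyl to 2,4-dichlorophenyl raises it (a 2.5-fold higher number from compound 1 to compound 3 (0.39 log units; beyond the scatter)). Both steps are modest and beyond the scatter, so the position responds to the choice of group, yet none of the three groups moves the number far, and the 4-cyanophenyl of compound 1 still gives the lowest value of the set. Nothing available explains this order, and this single swap changes the halogen and the number of groups on the phenyl ring at once, so it cannot show which of the two changes moved the number.

The compounds shown leave open whether one chlorine alone, in either of the two places it occupies in compound 3, would give the same value. They also leave open how an amine, a carboxylic acid or a methoxy group on this phenyl ring would compare with the nitrile and the halogens.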